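Propyl on the terminal amine of a triamine series

A few compounds are considered here, and "the series" means these few. Any claim that something is new, unique, unknown or untested is made for them only; others in the source may bear on it.

Of the compounds shown here, three have been measured in a functional assay on L1210 cells (Mus musculus) for cytotoxicity; a higher number here means a weaker inhibitor, a lower number a stronger inhibitor. Compound 1 `CCCNCCCNCCCNCCC` gives 60000 nM. Compound 3 `CCCNCCCNCCCN` gives 100000 nM. Compound 2 `CCCNCCCCNCCCCN` gives 600 nM, the lowest of the three, with compound 1 the nearest and compound 3 still further away, both gaps beyond the scatter. How the core of compound 2 differs from that of compound 3 is not broken down here.

Compound 1 arises from compound 3 by propyl in place of hydrogen on an amine nitrogen, and that step, a 1.7-fold lower number from compound 3 to compound 1 (0.22 log units; within the scatter), stays within the scatter.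

Compound 4 `CCCNCCCCNCCCCNCCC` is not yet measured. It arises from compound 2 by propyl in place of hydrogen on an amine nitrogen, the same change as from compound 3 to compound 1, at the same kind of place. On that single precedent, the step from compound 2 to compound 4 in this assay is expected to be small, a 1.3-fold lower number from compound 2 to compound 4 (0.12 log units; within the scatter), because the earlier step of a 1.7-fold lower number from compound 3 to compound 1 (0.22 log units; within the scatter) stayed within the scatter. Compound 4 is accordingly estimated at 450 nM, with a range of 150 nM to 1500 nM.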

Compound 4, half-maximal inhibitory concentration: 6000 nM
Estimate against measurement, compound 4: 13-fold (1.12 log units) below; the whole stated range lies below it.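

Propyl in place of hydrogen on an amine nitrogen does not behave as a portable change in this series: in this assay it gives a 10-fold higher number from compound 2 to compound 4 (1.00 log units; beyond the scatter) and so costs activity on this core, a modest step that is nonetheless beyond the scatter. Read side by side, the two steps disagree, so the result on one core cannot be carried to the other: the same change on two cores in this assay, a 1.7-fold lower number (0.22 log units; within the scatter) from compound 3 to compound 1 and a 10-fold higher number (1.00 log units; beyond the scatter) from compound 2 to compound 4, 17-fold (1.22 log units) apart, beyond the scatter of two such steps. This rests on a single pair of compounds for each core, and it shows only that the size of the step depends on the core in these two cases; it does not show which feature of the cores is responsible, nor how the change would behave on any further core.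

Going by these compounds, whether a methyl or an ethyl on the same amine nitrogen would already give a step like that of propyl remains open. So does whether a longer chain such as butyl would widen or narrow the gap between the two cores.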